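The source may report more compounds than this note shows. Statements on the series, on what has been measured and on what is new or still open speak of the compounds shown alone.

Compound 3, `C=C(Br)C(=O)Nc1cccc(-c2cn3nc(-c4ccccc4)sc3n2)c1`, gives the lowest number in this set in a functional assay on L1210 cells (Mus musculus) for inhibition, read by cell counting, with a stated time of 2 days; on this read-out lower numbers stand for stronger inhibition and higher numbers for weaker inhibition. Compound 2, `C=C(Br)C(=O)Nc1cccc(-c2cn3nc(-c4ccc(Cl)cc4)sc3n2)c1`, gives 1400 nM in this assay, and compound 3 gives 600 nM. Compound 1, `Nc1cccc(-c2cn3nc(Cc4ccc(Cl)cc4)sc3n2)c1`, which carries a free amine where the others carry a bromoacrylamide, gives 16000 nM in this assay, the highest of the three numbers.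

Compound 4, `C=C(Br)C(=O)Nc1cccc(-c2cn3nc(Cc4ccc(Cl)cc4)sc3n2)c1`, differs from compound 3 in one place: 4-chlorobenzyl in place of phenyl on an aromatic carbon. Within the data shown here, no measured pair shows a benzyl in place of a phenyl on the shared core, so that part of the change is uncharted. Among the measured compounds shown here, the only step that bears on it is the one in which hydrogen replaced chloro on an aromatic carbon: a 2.3-fold lower number from compound 2 to compound 3 (0.37 log units; beyond the scatter). Running that step backwards, a chloro on the ring is expected to push the number up by a modest amount, and the added methylene is expected to shift it little, or somewhat in the same direction, given that compound 1 with the same 4-chlorobenzyl gives 16000 nM. The expected step is therefore a 2.5-fold higher number from compound 3 to compound 4 (0.40 log units; beyond the scatter). Compound 4 is thus estimated at 1500 nM in this assay, with a likely range from 500 nM to 5000 nM.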

Compound 4, half-maximal inhibitory concentration: 2300 nM
Beside the measured number, compound 4's estimate is 1.5-fold (0.19 log units) below it, and the stated range covers the measured number.
By their numbers in this assay, from the lowest: compound 3; then compounds 2 and 4 (each within the scatter of the next); then compound 1.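

In this assay, among these compounds, the step of a 7.0-fold lower number from compound 1 to compound 4 (0.84 log units; beyond the scatter) isolates the (1-bromoethenyl)carbonyl group on the nitrogen for the first time, as no earlier pair changed that group alone. At the aromatic carbon of the five-membered ring, the change from 4-chlorophenyl to 4-chlorobenzyl gives a 1.6-fold higher number from compound 2 to compound 4 (0.22 log units; within the scatter) and stays within the scatter, so with the chloro present these two groups cannot be told apart in this assay. Against plain phenyl, the step of a 3.8-fold higher number from compound 3 to compound 4 (0.58 log units; beyond the scatter) is beyond the scatter, and compound 3 keeps the lowest number of the four.

An unsubstituted benzyl, which would separate the chloro from the added carbon, is absent, as is a longer chain such as 2-phenylethyl at this position. No available evidence explains any of these steps.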